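The source may hold more compounds than are shown below. What is called first, only, known or untested is meant among the compounds shown, and "the series" means these compounds.

Measured in an ADME assay on PC-12 cells (Rattus norvegicus) for cytotoxicity, read by WST assay, with a stated time of 24 h; on this read-out lower numbers stand for higher toxicity in this test and higher numbers for lower toxicity in this test:
- compound 1 `O=C(/C=C/c1ccccc1O)CC(=O)/C=C/c1cc(O)ccc1O`: 38000 nM
- compound 2 `O=C(/C=C/c1ccc(O)c(O)c1)/C=C/c1ccccc1O`: 34000 nM
- compound 3 `O=C(/C=C/c1cccc(O)c1)/C=C/c1ccc(O)c(O)c1`: > 100000 nM (a limit)

Compound 3 has no number on this read-out, only the limit > 100000 nM.

Compound 4 `O=C(/C=C/c1ccc(O)cc1)/C=C/c1ccc(O)c(O)c1` carries 4-hydroxyphenyl in place of the 3-hydroxyphenyl of compound 3, on a double-bonded chain carbon bound to a double-bonded chain carbon (4-hydroxyphenyl in place of 3-hydroxyphenyl on a double-bonded chain carbon bound to a double-bonded chain carbon).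

Going by the values given here, one measured step bears on this place: an at least 2.9-fold higher number from compound 2 to compound 3 (0.46 log units; beyond the scatter). It concerns a different pair of groups, so it gives only a rough guide to size, and its direction need not carry over. Compound 4 may stay at the limit. It may instead move back toward compound 2 at 34000 nM.

A modest shift to a lower number in this assay is expected, no larger than the measured step, and the expected step is an at least 1.4-fold lower number from compound 3 to compound 4 (0.15 log units; that floor lies within the scatter).

The estimate for compound 4 is 70000 nM, with an expected range of 25000 nM to 200000 nM.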

Compound 4, half-maximal cytotoxic concentration: 12000 nM
Estimate against measurement, compound 4: 5.8-fold (0.77 log units) above; measured number outside the range, below it.
By their numbers in this assay, from the lowest: compound 4; then compounds 2 and 1 (each within the scatter of the next). At a limit, above all of these: compound 3.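

In this assay, the three hydroxyphenyl groups on a double-bonded chain carbon bound to a double-bonded chain carbon do not give a one-way trend: 4-hydroxyphenyl gives the lowest number, with an at least 8.3-fold lower number from compound 3 to compound 4 (0.92 log units; beyond the scatter) and a 2.8-fold lower number from compound 2 to compound 4 (0.45 log units; beyond the scatter). The earlier compounds shown here showed only the rise of an at least 2.9-fold higher number from compound 2 to compound 3 (0.46 log units; beyond the scatter), whereas 4-hydroxyphenyl goes beyond 2-hydroxyphenyl in the opposite direction, so the identity of the isomer matters at this place. The value of compound 3 is a limit and not a number, so the size of its step to compound 4 remains a floor: the limit of > 100000 nM in this assay, at which 1 of the 4 values shown sits.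

The compounds shown give no reason for this order among the three groups. On these data alone, it also remains open whether an aminophenyl or carboxyphenyl group at this place would give a number near that of compound 4.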